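The source may hold more compounds than are shown below. What is called first, only, known or untested is meant among the compounds shown, and "the series" means these compounds.

In an ADME assay on cells (Splenocyte, Mus musculus, strain BALB/c) for cytotoxicity, read by thymidine incorporation, with a stated time of 24 h (a higher number here means a weaker inhibitor, a lower number a stronger inhibitor), compound 1 `O=C(CCN1CCN(c2ccnc3cc(Cl)ccc23)CC1)N/N=C/c1ccc([N+](=O)[O-])cc1` gives 12100 nM, while compound 2 `CC(C)Oc1ccc(/C=N/NC(=O)CCN2CCN(c3ccnc4cc(Cl)ccc34)CC2)cc1` gives 3600 nM. Among the measured compounds shown here, the single change between them is a 3.4-fold lower number from compound 1 to compound 2 (0.53 log units; beyond the scatter). For the measured compounds named here, compound 2 therefore holds the lower of the two numbers measured so far, with compound 1 the only neighbour, a modest distance above it. Compound 3 `O=C(CCN1CCN(c2ccnc3cc(Cl)ccc23)CC1)N/N=C/c1cccc(Cl)c1` has not yet been tested; compared with compound 2 it carries 3-chlorophenyl in place of 4-isopropoxyphenyl on a carbon with a double bond to nitrogen, that is, 3-chlorophenyl in place of 4-isopropoxyphenyl on a carbon with a double bond to nitrogen. Going by the values given here, only the step from compound 1 to compound 2 bears on this change, since it also altered the group on that aromatic ring, and it was modest. Compound 3 gives up the isopropoxy group that went with the lower number, so compound 3 is expected to show a somewhat higher number in this assay, about a 1.8-fold higher number from compound 2 to compound 3 (0.26 log units; within the scatter), a shift that may still lie within the scatter. The estimate for compound 3 is 6500 nM, with a likely range from 2500 nM to 17000 nM.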

Compound 3, half-maximal inhibitory concentration: > 100000 nM
Compound 3 gave a limit, no number; the forecaster's own chance of this, stated with the estimate: 5%; middle value at least 15-fold (1.18 log units) from the limit.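

In this assay compound 3 gives a limit and not a number: the limit of > 100000 nM in this assay, at which 1 of the 3 values shown sits. Even so, the aromatic group on the carbon with a double bond to nitrogen proves able to move this read-out much further than the earlier pair suggested, with an at least 27-fold higher number from compound 2 to compound 3 (1.44 log units; beyond the scatter) and an at least 8.2-fold higher number from compound 1 to compound 3 (0.91 log units; beyond the scatter). Moving between 4-nitrophenyl and 4-isopropoxyphenyl still gave measured numbers in both compounds, whereas 3-chlorophenyl in place of either one takes the result to the limit.

As far as these compounds go, the change to 3-chlorophenyl alters both the group on the ring and where it sits, so these compounds cannot separate the two, and the true size of the step stays unknown. A 4-chlorophenyl group would show whether the chlorine itself or its place on the ring goes with the jump.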